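Isopropyl to tert-butyl on the amide of compound 2

This account rests on a few compounds, and the source may have more. Where it says the series, first, only, none or still open, it means among the compounds named here.

Compound 1 `Cc1cc(C(=O)O)nn1Cc1cc(Cl)cn2nc(C(C)C)cc12` reaches only a limit of the assay in an assay on CHO-K1 cells for displacement of a labelled ligand from prostaglandin E2 receptor EP1 subtype (Homo sapiens), read by scintillation counting, with a stated time of 45 min (on this read-out higher numbers stand for weaker inhibition and lower numbers for stronger inhibition), namely > 1000 nM. Among the compounds with values here, compound 2 `Cc1cc(C(=O)NC(C)C)nn1Cc1cc(Cl)cc2cc(-c3ccccc3)oc12` is the one member of the pair with a number on this read-out, and in this assay compound 2 gives 10 nM. Within the data shown here, it therefore stands alone as the only measured value, the other entry being a limit, as noted by the limit of > 1000 nM in this assay, at which 1 of the 2 values shown sits.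

Compound 3 `Cc1cc(C(=O)NC(C)(C)C)nn1Cc1cc(Cl)cc2cc(-c3ccccc3)oc12` differs from compound 2 by methyl in place of hydrogen on a saturated chain carbon bound to an amide-type nitrogen and two saturated chain carbons. Among the measured compounds shown here, no measured pair shows what such a change does. The step is expected to be small, with neither direction favoured beyond the usual scatter, so that a 1.5-fold higher number from compound 2 to compound 3 (0.18 log units; within the scatter) is the estimated outcome. Compound 3 is accordingly expected to give 15 nM in this assay, with a range from 4 nM to 60 nM.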

Compound 3, half-maximal inhibitory concentration: 10 nM
Beside the measured number, compound 3's estimate is 1.5-fold (0.18 log units) above it, within the range that was stated.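

Isopropyl to tert-butyl on the amide gives no change at the digits printed from compound 2 to compound 3 (within the scatter) in this assay, and this is the only pair shown that reads this position. The saturated chain carbon bound to the amide-type nitrogen thus takes one more methyl without a step beyond the scatter, so the number in this series does not rest on that carbon keeping its hydrogen. Nothing measured here gives a reason for this outcome.

The compounds shown leave open what a longer chain such as n-butyl, a cyclopropyl ring, or an amine or hydroxyl on the chain would do at this amide nitrogen. Within the data shown here, they also leave open whether the same methyl has so little effect on any core other than the one shared by compound 2 and compound 3.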